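Carboxymethyl in Place of the Hydroxymethyl-Ethyl Amide Substituent

The source may hold more compounds than are shown below. What is called first, only, known or untested is meant among the compounds shown, and "the series" means these compounds.

Measured compounds:
Compound 1, `CCC(CC)(c1ccc(OCC(O)C(C)(C)C)c(C)c1)c1ccc(C(=O)NCCCO)n1C`: 150 nM
Compound 2, `CCC(CC)(c1ccc(OCC(O)C(C)(C)C)c(C)c1)c1ccc(C(=O)N[C@@H](C)CO)n1C`: 570 nM
Compound 3, `CCn1c(C(=O)N[C@@H](C)CO)ccc1C(CC)(CC)c1ccc(OCC(O)C(C)(C)C)c(C)c1`: 1.06 nM

In an assay on HL-60 cells for agonist activity at vitamin D3 receptor (Homo sapiens), with a stated time of 96 h (a higher number here means that more compound is needed for the effect, a lower number that less compound is needed), compound 2 gives the highest number of the three. Its nearest neighbour is reached by a 3.8-fold higher number from compound 1 to compound 2 (0.58 log units; beyond the scatter), its furthest by a 540-fold lower number from compound 2 to compound 3 (2.73 log units; beyond the scatter).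

Compound 4, `CCC(CC)(c1ccc(OCC(O)C(C)(C)C)c(C)c1)c1ccc(C(=O)NCC(=O)O)n1C`, differs from compound 2 by carboxymethyl in place of 1-(hydroxymethyl)ethyl on an amide-type nitrogen. Among the measured compounds shown here, of the two measured steps only the one from compound 1 to compound 2 sits on the same amide nitrogen, and it was modest; the large step to compound 3 concerns the chain on the aromatic nitrogen, which compound 4 keeps unchanged. A modest step in this assay is therefore expected, with its direction open. Compound 4 is estimated at 450 nM, within 120 nM to 1800 nM, an expected 1.3-fold lower number from compound 2 to compound 4 (0.10 log units; within the scatter).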

Compound 4, half-maximal effective concentration: 4950 nM
Estimate against measurement, compound 4: 11-fold (1.04 log units) below; measured number above the stated range.
By their numbers in this assay, from the lowest: compound 3; then compound 1; then compound 2; then compound 4.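

In this assay, carboxymethyl on the amide-type nitrogen moves the number upward, an 8.7-fold higher number from compound 2 to compound 4 (0.94 log units; beyond the scatter), and further still against the straight chain, a 33-fold higher number from compound 1 to compound 4 (1.52 log units; beyond the scatter). The groups that leave and enter have the same counts of heavy atoms, hydrogen-bond donors and acceptors, so these counts alone do not track the result at this position. Nothing available accounts for the rise.

The compounds shown leave open how a methyl ester or an amine at the end of this chain would read. They also leave open whether the ethyl chain on the aromatic nitrogen of compound 3 would lower the number with carboxymethyl on the amide-type nitrogen.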